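Compound 3 and compound 4: one stereocentre drawn differently

The source may hold more compounds than are shown below. What is called first, only, known or untested is meant among the compounds shown, and "the series" means these compounds.

Measured so far:
Compound 1 `CSc1cccc(NC(=O)c2cc3ccc(C(F)(F)F)cc3n2CC(C)C(=O)NC2CCCC2)c1` gives 7100 nM
Compound 2 `CSc1cccc(N2C(=O)CN(c3ccccc3)CC2C(=O)NC2CCCC2)c1` gives > 50000 nM (a limit of the assay)
Compound 3 `O=C(NC1CCCC1)[C@H]1CN(c2ccc(C(F)(F)F)cc2)CC(=O)N1c1ccc2ccsc2c1` gives 10000 nM

In an ADME assay on HepG2 cells (Homo sapiens) for cytotoxicity (a higher number here means that more compound is tolerated, a lower number that less compound is tolerated), compound 3 stands at 10000 nM and compound 1 stands at 7100 nM with the two values within the usual scatter of each other. Compound 2 gives only a limit of the assay (> 50000 nM) and not a number. For the measured compounds named here, no two measured compounds differ in one place, so no measured step is available as a guide.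

Compound 4 `O=C(NC1CCCC1)C1CN(c2ccc(C(F)(F)F)cc2)CC(=O)N1c1ccc2ccsc2c1` departs from compound 3 in one respect (the two compounds have the same atoms and bonds; at least one stereo element is drawn with a configuration in one of them and without one in the other: 1 of 1 stereo elements differ; a stereocentre at a saturated ring carbon is drawn R in compound 3 and without a configuration in compound 4): the two compounds have the same atoms and bonds, and a stereocentre at a saturated ring carbon is drawn R in compound 3 and without a configuration in compound 4. No sizeable step is expected in this assay. The expectation rests on compound 3 at 10000 nM as the closest measured structure. The expected size of the change is no change at the digits printed from compound 3 to compound 4 (within the scatter) and this is estimated to stay within the scatter. For compound 4 the estimated value is 10000 nM with an expected range (5000 nM to 22000 nM).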

Compound 4, half-maximal cytotoxic concentration: 10000 nM
For compound 4 middle estimate and measured number coincide at the digits printed, within the range that was stated.
By their numbers in this assay, from the lowest: compounds 1, 3 and 4 (each within the scatter of the next). At a limit, above all of these: compound 2.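

In this assay, for the compounds shown here, the one readable step shows no change at the digits printed from compound 3 to compound 4 (within the scatter), and it is the only comparison here that isolates a single place. A stereocentre at a saturated ring carbon drawn R or drawn without a configuration therefore makes no difference that this measurement can separate in this pair. The reading rests on a difference of drawing alone, since the atoms and bonds are the same: the fact that one of compounds 3 and 4 is drawn with a defined configuration and the other without, at the place where they differ

The compounds shown leave open how a compound drawn S at this carbon would read in this assay, and whether a nitrile in place of the trifluoromethyl group would shift the number. Going by these compounds alone, compound 2 gives > 50000 nM, which is a limit of the assay and not a number, and no single-place step links it to the others.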